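The compounds below may be only part of what the source reports. "The series", "measured", "known", "first", "only" and "open" are said of these compounds alone.

Series notes, antiproliferative readout on the glioblastoma line.

Of the compounds shown here, three have numbers so far. Compound 3 `Cc1nc(-c2ccc(Cl)cc2)sc1C(=O)CSc1nc(-c2ccc(Cl)cc2)c(C#N)c(=O)[nH]1` and compound 1 `COc1ccc(-c2nc(C)c(C(=O)CSc3nc(-c4ccc(Cl)cc4)c(C#N)c(=O)[nH]3)s2)cc1` share one core; compound 2 `Cc1nc(-c2ccc(Cl)cc2)sc1C(=O)CSc1nc(N)c(C#N)c(-c2ccc(Cl)cc2)n1` has a different core, and the difference between the two cores is not broken down here. In a functional assay on U-87MG ATCC cells for antiproliferative activity against U-87 MG (Homo sapiens), read by MTT assay, with a stated time of 48 h (a lower number here means a stronger inhibitor, a higher number a weaker inhibitor), compound 3 gives 53000 nM. In this assay compound 1 gives 45900 nM. In this assay compound 2 gives 3420 nM, the lowest number of the three and beyond the scatter against both of the others.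

For the measured compounds named here, the one step within the shared core is methoxy in place of chloro on an aromatic carbon, and it reads a 1.2-fold lower number from compound 3 to compound 1 (0.06 log units; within the scatter). On that core the swap of chloro for methoxy therefore leaves the number where it was.

Compound 4 `COc1ccc(-c2nc(SCC(=O)c3sc(-c4ccc(Cl)cc4)nc3C)nc(N)c2C#N)cc1` is the unmeasured analogue of compound 2 built with the same change: methoxy in place of chloro on an aromatic carbon. The place line is word for word the same as for the step from compound 3 to compound 1, so this is the same change carried onto the core of compound 2. Going by the values given here, the only evidence for its size is the single step on the other core, which was within the scatter; nothing on the core of compound 2 itself is known.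

Compound 4 is therefore expected to sit close to compound 2, with an expected step of a 1.0-fold lower number from compound 2 to compound 4 (0.02 log units; within the scatter) in this assay, resting on the flat step from compound 3 to compound 1 of a 1.2-fold lower number from compound 3 to compound 1 (0.06 log units; within the scatter). For compound 4 the estimate in this assay is 3300 nM, with the range expected to run from 1300 nM to 8500 nM.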

Compound 4, half-maximal inhibitory concentration: 10600 nM
The estimate for compound 4 lay 3.2-fold (0.51 log units) below the measured number; measured number above the stated range.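

On the core of compound 2, the swap from 4-chlorophenyl to 4-methoxyphenyl is not flat in this assay: it gives a 3.1-fold higher number from compound 2 to compound 4 (0.49 log units; beyond the scatter) and stands as a modest step. Compound 2 and compound 3 each carry two 4-chlorophenyl groups, and the structures show the swap falling on a different one of them in each step, so this pair of steps does not separate the effect of the core from that of which group was changed, and it gives no rule for the series. What it does show is that a flat result on one core cannot be carried over unchanged to the other, as the two steps differ in size: the same change on two cores in this assay, a 1.2-fold lower number (0.06 log units; within the scatter) from compound 3 to compound 1 and a 3.1-fold higher number (0.49 log units; beyond the scatter) from compound 2 to compound 4, 3.6-fold (0.55 log units) apart, beyond the scatter of two such steps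

Still open, from the compounds shown here alone, is whether the swap at the other 4-chlorophenyl group of compound 2 or compound 3 would give a step like either of these. Also open is how other groups at the same place, such as fluoro, trifluoromethyl or hydroxyl, would compare on the two cores, since chloro and methoxy are the only pair shown.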